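The source may report more compounds than this note shows. Statements on the series, on what has been measured and on what is new or still open speak of the compounds shown alone.

Working notes on the series.

Compound 1 `CN(C)CCNc1cc2c(cn1)cc(NC(=O)c1ccccc1)c(=O)n2C` is the reference point. In a functional assay on MDA-MB-468 cells (Homo sapiens) for antiproliferative activity, read by MTT assay, with a stated time of 48 h (on this read-out lower numbers stand for stronger inhibition and higher numbers for weaker inhibition), compound 1 gives 18300 nM, the second highest of the three numbers in hand. Compound 2 `CN(C)CCNc1cc2c(cn1)cc(NC(=O)c1ccc(N)cc1)c(=O)n2C` gives 20400 nM in this assay; the step of a 1.1-fold higher number from compound 1 to compound 2 (0.05 log units; within the scatter) puts the two within the scatter of each other. Within the data shown here, compound 3 `COc1ccc(C(=O)Nc2cc3cnc(N4CCN(C)CC4)cc3n(C)c2=O)cc1` gives 12600 nM in this assay; its value and that of compound 1 also lie within the scatter, and no single-point step connects the two, since compound 3 carries a different amine on the core as well.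

Compound 4 `COc1ccc(C(=O)Nc2cc3cnc(NCCN(C)C)cc3n(C)c2=O)cc1` is not yet measured. It differs from compound 1 in one place: methoxy in place of hydrogen on an aromatic carbon. Among the measured compounds shown here, the only measured single-point step touching the same aromatic ring of carbon only, from compound 1 to compound 2, introduced a different group on that ring and stayed within the scatter. Compound 3 carries the methoxy on that same ring, but with the other amine, so it informs only loosely. For the measured compounds named here, no measured step therefore points to a change beyond the scatter in this assay for the methoxy in place of hydrogen on an aromatic carbon. The expected step is a 1.1-fold lower number from compound 1 to compound 4 (0.06 log units; within the scatter). Compound 4 is expected to give about 16000 nM in this assay, with a range from 7000 nM to 36000 nM.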

Compound 4, half-maximal inhibitory concentration: 15700 nM
Beside the measured number, compound 4's estimate is 1.0-fold (0.01 log units) above it; the range from low to high includes it.
By their numbers in this assay, from the lowest: compounds 3, 4, 1 and 2 (each within the scatter of the next).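

In this assay the methoxy group on the aromatic ring of carbon only, para to a large group, gives a 1.2-fold lower number from compound 1 to compound 4 (0.07 log units; within the scatter) and, set against the amino group at the same place, a 1.3-fold lower number from compound 2 to compound 4 (0.11 log units; within the scatter) so that hydrogen, amino and methoxy at this place now all stand within the scatter of one another. With 4-methoxyphenyl held constant, exchanging the amine on the shared core gives a 1.2-fold higher number from compound 3 to compound 4 (0.10 log units; within the scatter) and this first reading of that change in isolation also shows no separation between 4-methylpiperazin-1-yl and (2-(dimethylamino)ethyl)amino. No supporting data are at hand to explain the size of these steps.

The three groups shown at this place leave open whether a carboxylic acid, a trifluoromethyl group or a larger group such as phenyl at the same place would produce a step beyond the scatter. Among these compounds, on the amine side, only two groups can be compared, so a longer chain or a morpholine ring remains an open question for the series.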